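The compounds below may be only part of what the source reports. "The series", "measured", "known", "first", "only" and "open" are said of these compounds alone.

In an ADME assay on MRC5 cells (Homo sapiens) for inhibition, with a stated time of 72 h (on this read-out higher numbers stand for an effect only at larger amounts of compound and lower numbers for an effect already at smaller amounts), compound 1 (`COc1cccc(OC)c1C(=O)Nc1c[nH]nc1C(=O)NN1CCOCC1`) gives > 50000 nM, which is a limit of the assay and not a number. It therefore stands at the limit of > 50000 nM in this assay, at which 1 of the 3 values shown sits. Compound 4 (`CCCCCNC(=O)c1n[nH]cc1NC(=O)c1c(OC)cccc1OC`) has pentyl in place of morpholin-4-yl on an amide-type nitrogen.

For the measured compounds named here, no measured step makes this same change. The closest evidence comes from two compounds that carry neither group on that nitrogen: compound 2 (`CO[C@H]1CC[C@H](NC(=O)c2n[nH]cc2NC(=O)c2ccccc2)CC1`) gives 800 nM, and compound 3 (`CO[C@H]1CC[C@H](NC(=O)c2n[nH]cc2NC(=O)c2cc(Cl)cc(Cl)c2)CC1`) gives 13000 nM. Both give real numbers, though each also differs from compound 1 elsewhere, so they offer only a loose guide. Going by the values given here, the one measured step, a 16-fold higher number from compound 2 to compound 3 (1.21 log units; beyond the scatter), is large, but it comes from 3,5-dichlorophenyl in place of phenyl on a carbonyl carbon, not from the change at hand. Among the compounds with values here, it shows only that one swap can move the number a long way in this assay.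

A clear move to a lower number is therefore expected, though with wide uncertainty, and the estimated change is an at least 4.1-fold lower number from compound 1 to compound 4 (0.61 log units; beyond the scatter). For compound 4 the estimated value is 12000 nM, with an expected range of 2000 nM to 50000 nM.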

Compound 4, half-maximal effective concentration: > 50000 nM
Compound 4: no number, only a limit; the forecaster's own chance of this, stated with the estimate: 25%; at least 4.1-fold (0.61 log units) between middle value and limit.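

Compound 1 and compound 4 both give a limit rather than a number in this assay, so the step between them cannot be read: the limit of > 50000 nM in this assay, at which 2 of the 4 values shown sit.

Going by these compounds, whether pentyl or morpholin-4-yl on that amide-type nitrogen gives the lower number stays open.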